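The source may report more compounds than this note shows. Statements on the series, on what has been measured and on what is new or still open speak of the compounds shown alone.

Compound 1, `Fc1cccc(-c2nc(Nc3ccccc3)c3ccccc3n2)c1`, gives > 50000 nM in a functional assay on HL-60 cells (Homo sapiens) for cytotoxicity, read by MTT assay, with a stated time of 48 h; a higher number here means a weaker inhibitor, a lower number a stronger inhibitor.
Compound 2, `Fc1ccc2nc(-c3ccccc3)nc(Nc3ccccc3)c2c1`, gives > 50000 nM in this assay.

Both of these numbers are limits of the assay rather than measured values. Among the measured compounds shown here, compound 2 therefore stands at the limit, and so does compound 1 (the limit of > 50000 nM in this assay, at which 2 of the 2 values shown sit), so no step between measured compounds can be given. Compound 3, `Fc1cccc(-c2nc(Nc3ccccc3)c3cc(F)ccc3n2)c1`, differs from compound 2 by fluoro in place of hydrogen on an aromatic carbon. In this assay the expected step that the limit leaves unreadable from compound 2 to compound 3 is none beyond the scatter. Compound 3 is thus estimated at 80000 nM, between 30000 nM and 300000 nM, and is expected most likely to return only a limit again.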

Compound 3, half-maximal inhibitory concentration: 48300 nM
For compound 3 the middle estimate is 1.7-fold (0.22 log units) above the measured one; the range from low to high includes it.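

In this assay, compound 3 returns a number rather than a limit, so fluoro in place of hydrogen on an aromatic carbon can now be given a step. Going from phenyl to 3-fluorophenyl gives an at least 1.0-fold lower number from compound 2 to compound 3 (0.01 log units; that floor lies within the scatter), and adding fluoro to the shared core gives an at least 1.0-fold lower number from compound 1 to compound 3 (0.01 log units; that floor lies within the scatter). Both steps are only floors, and their true size cannot be read: the limit of > 50000 nM in this assay, at which 2 of the 3 values shown sit.

The compounds shown leave open whether either fluoro contributes more than the other. They also leave open whether an amine or a methoxy group at the same place would shift the number beyond the scatter.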